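This account rests on a few compounds, and the source may have more. Where it says the series, first, only, none or still open, it means among the compounds named here.

In a functional assay on MCF7 cells (Homo sapiens) for antiproliferative activity, read by MTT assay, with a stated time of 72 h (on this read-out higher numbers stand for weaker inhibition and lower numbers for stronger inhibition), three compounds built on a shared core have been measured. Compound 1 (`O=C(COc1ccc(C(=O)/C=C/c2ccc(Cl)cc2Cl)cc1)N[C@H]1CCOC1=O`) gives 34400 nM, compound 2 (`O=C(COc1ccc(C(=O)/C=C/c2ccccc2Cl)cc1)N[C@H]1CCOC1=O`) gives 17400 nM, and compound 3 (`O=C(COc1ccc(C(=O)/C=C/c2cccc(Br)c2)cc1)N[C@H]1CCOC1=O`) gives 28300 nM. Compound 3 does not separate from the other two: a 1.2-fold lower number from compound 1 to compound 3 (0.08 log units; within the scatter) and a 1.6-fold higher number from compound 2 to compound 3 (0.21 log units; within the scatter) both lie within the scatter, as does a 2.0-fold lower number from compound 1 to compound 2 (0.30 log units; within the scatter).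

Compound 4 (`O=C(COc1ccc(C(=O)/C=C/c2ccccc2Br)cc1)N[C@H]1CCOC1=O`) has the same atoms as compound 3, joined differently: 2-bromophenyl in place of 3-bromophenyl on a double-bonded chain carbon bound to a double-bonded chain carbon. In words, 2-bromophenyl stands in place of 3-bromophenyl on a double-bonded chain carbon bound to a double-bonded chain carbon.

For the measured compounds named here, no measured step makes exactly this change. The nearest is a 1.6-fold higher number from compound 2 to compound 3 (0.21 log units; within the scatter), which exchanges 2-chlorophenyl for 3-bromophenyl and so leads to compound 3 from the measured compound closest to compound 4 in its aryl group. That step stays within the scatter, as do the other two, so no step beyond the scatter is expected in this assay, and any direction is only a slight lean towards compound 2.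

The expected change is small, a 1.3-fold lower number from compound 3 to compound 4 (0.11 log units; within the scatter). Compound 4 is estimated at 22000 nM, with an expected range from 11000 nM to 42000 nM.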

Compound 4, half-maximal inhibitory concentration: 15300 nM
The estimate for compound 4 lay 1.4-fold (0.16 log units) above the measured number; low and high end bracket the measured number.
By their numbers in this assay, from the lowest: compounds 4, 2, 3 and 1 (each within the scatter of the next, the first and the last beyond it).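

In this assay, for the compounds shown here, 2-bromophenyl in place of 3-bromophenyl on a double-bonded chain carbon bound to a double-bonded chain carbon gives a 1.8-fold lower number from compound 3 to compound 4 (0.27 log units; within the scatter), so these two isomers, the first pair in the set with the same atoms joined differently, do not separate. Bromo in place of chloro on an aromatic carbon gives a 1.1-fold lower number from compound 2 to compound 4 (0.06 log units; within the scatter), so compound 2 and compound 4 also read alike, and this halogen exchange makes no difference that the assay can resolve. Going by these compounds alone, the new compound also provides the only step in the set that passes the scatter, a modest one: 2-bromophenyl in place of 2,4-dichlorophenyl gives a 2.2-fold lower number from compound 1 to compound 4 (0.35 log units; beyond the scatter), while the matching step to compound 2 stays within it.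

Nothing at hand explains any of these steps. As far as these compounds go, it remains open whether a different kind of group on the phenyl ring, such as an amine, a methoxy group or a carboxylic acid, would move the number clearly away from these halogen-bearing compounds, and whether a 4-bromophenyl group would separate from its two isomers.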